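The compounds below may be only part of what the source reports. "The series", "measured", "known", "first", "only" and "open" are said of these compounds alone.

Measured compounds:
- compound 1 `CCCCNc1nc(N)nc(C)c1CCCN1CCCCCC1`: 178 nM
- compound 2 `CCCCNc1nc(N)nc(C)c1CCCn1c(C)nc2ccccc21`: 366 nM

Of the compounds shown here, two sharing the same core have been measured in an assay on HEK293 cells for agonist activity at Toll-like receptor 8 (Homo sapiens), read by spectrophotometry; on this read-out lower numbers stand for an effect already at smaller amounts and higher numbers for an effect only at larger amounts of compound. Compound 1 gives 178 nM, the lower of the two numbers. Compound 2, which carries a fused aromatic system at the end of the same three-carbon chain, gives 366 nM in this assay, a gap that lies beyond the usual scatter, so compound 1 stands as the stronger of the pair on the numbers shown.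

The next compound, compound 3 `CCCCNc1nc(N)nc(C)c1CCCCc1ccccc1`, has not yet been measured. It differs from compound 1 in one place: benzyl in place of azepan-1-yl on a saturated chain carbon, three bonds along the chain from an aromatic carbon.

Going by the values given here, with no measured step of this kind to lean on, the expectation rests on the two values alone. Because compound 2 gives 366 nM with an aromatic group in place of the saturated ring, a move in the same direction is expected here, and the step of a 2.2-fold higher number from compound 1 to compound 3 (0.35 log units; beyond the scatter) is estimated to be a modest rise, around the edge of the scatter rather than far beyond it. For compound 3 the estimate in this assay is 400 nM, with a range from 120 nM to 1500 nM.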

Compound 3, half-maximal effective concentration: 857 nM
Estimate against measurement, compound 3: 2.1-fold (0.33 log units) below; measured number inside the range.
By their numbers in this assay, from the lowest: compound 1; then compound 2; then compound 3.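

In this assay, going by these compounds alone, the exchange of azepan-1-yl for benzyl on a saturated chain carbon, three bonds along the chain from an aromatic carbon, gives a 4.8-fold higher number from compound 1 to compound 3 (0.68 log units; beyond the scatter) and so provides the first direct reading of a single change at this position. The two groups have the same count of heavy atoms, yet a seven-membered non-aromatic ring holding a nitrogen and a hydrogen-bond acceptor gives way to a six-membered aromatic ring of carbon only, so this position responds to the kind of group and not merely to its heavy-atom count. No measurement shown here explains the step, and it cannot say which of these differences matters.

As far as these compounds go, it remains open whether a cycloheptyl group, a saturated ring of carbon only, would stand nearer compound 1 or compound 3, which would separate the loss of the ring nitrogen from the arrival of the aromatic ring. From the compounds shown here alone, it is also open how a smaller amine such as piperidin-1-yl or dimethylamino would read at this place.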